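This account rests on a few compounds, and the source may have more. Where it says the series, first, only, none or still open, it means among the compounds named here.

In an ADME assay on CEM-SS cells (Homo sapiens) for cytotoxicity, read by XTT assay, with a stated time of 6 days (a higher number here means that more compound is tolerated, a lower number that less compound is tolerated), compound 1 `CCCC(=O)OCSc1ccccc1C(=O)NCCCCC(N)=O` gives 51.7 uM and compound 2 `CCCC(=O)OCSc1ccccc1C(=O)NCCCCCC(N)=O` gives 16.3 uM, the lower of these two numbers. Compound 3 `CCCC(=O)OCSc1ccccc1C(=O)N[C@H]1CCC[C@H]1C(N)=O` gives 89.9 uM; 84.8 uM (2 entries). For the measured compounds named here, the only measured step, a 3.2-fold lower number from compound 1 to compound 2 (0.50 log units; beyond the scatter), is modest and concerns carbamoylmethyl in place of carbamoyl on a saturated chain carbon, so it bears only loosely on compound 4 `CCCC(=O)OCSc1ccccc1C(=O)N[C@@H]1CCC[C@H]1C(N)=O`. The change here is 2-carbamoylcyclopentyl in place of 5-carbamoylpentyl on an amide-type nitrogen, with 2-carbamoylcyclopentyl in place of 5-carbamoylpentyl on an amide-type nitrogen. Compound 3, which also carries 2-carbamoylcyclopentyl, stands at 89.9 uM; 84.8 uM (2 entries), so a moderate move to a higher number is expected in this assay. The expected step is a 4.3-fold higher number from compound 2 to compound 4 (0.63 log units; beyond the scatter). The estimated value for compound 4 is 70 uM, within a range of 30 uM to 150 uM.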

Compound 4, half-maximal toxic concentration: 43.7 uM
The estimate for compound 4 lay 1.6-fold (0.20 log units) above the measured number; the range from low to high includes it.
By their numbers in this assay, from the lowest: compound 2; then compounds 4 and 1 (each within the scatter of the next).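

In this assay, 2-carbamoylcyclopentyl in place of 5-carbamoylpentyl on the amide-type nitrogen gives a 2.7-fold higher number from compound 2 to compound 4 (0.43 log units; beyond the scatter). In place of 4-carbamoylbutyl, the same group gives a 1.2-fold lower number from compound 1 to compound 4 (0.07 log units; within the scatter), so the ring-bearing compound 4 cannot be told apart from the shorter-chain compound 1. Configuration also enters the picture at this position, with compound 3 at 89.9 uM; 84.8 uM (2 entries) and compound 4 at 43.7 uM, and the two values can be set side by side on this basis: the fact that compounds 3 and 4 differ only in the configuration as drawn

The compounds shown leave open how the other stereoisomers of this group would read. They also leave open whether a carboxylic acid in place of the carbamoyl group, or a 2-carbamoylcyclohexyl group, would give similar numbers.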